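Removing one methoxy group from compound 2

The source may hold more compounds than are shown below. What is called first, only, known or untested is meant among the compounds shown, and "the series" means these compounds.

Compound 1 `COc1ccc(-c2cc(/C=C/C(=O)c3ccc(N)cc3)[nH]n2)cc1` and compound 2 `COc1cc(-c2cc(/C=C/C(=O)c3ccc(N)cc3)[nH]n2)cc(OC)c1OC` share one core and differ only in how many methoxy groups they carry. In a functional assay on NCI-H522 cells (Homo sapiens) for inhibition, read by sulforhodamine B assay, with a stated time of 48 h (on this read-out lower numbers stand for higher toxicity in this test and higher numbers for lower toxicity in this test), compound 1 gives 7030 nM and compound 2 gives 9810 nM. Compound 2 stands at the higher of the two numbers, but its gap to compound 1 lies within the scatter, so the pair reads as equal. Compound 3 `COc1ccc(-c2cc(/C=C/C(=O)c3ccc(N)cc3)[nH]n2)cc1OC` is not yet measured. Relative to compound 2 the change is hydrogen in place of methoxy on an aromatic carbon — hydrogen in place of methoxy on an aromatic carbon. Among the measured compounds shown here, no measured pair covers this exact change. Since compound 1 at 7030 nM and compound 2 at 9810 nM sit within the scatter of each other, altering the methoxy count has shown no step beyond the scatter so far. The expected step is therefore a 1.2-fold lower number from compound 2 to compound 3 (0.08 log units; within the scatter), none beyond the scatter. Compound 3 is estimated to give 8200 nM in this assay, with a range of 3500 nM to 19000 nM.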

Compound 3, concentration lethal to 50% of the cells: 6300 nM
Compound 3: the middle estimate sits 1.3-fold (0.11 log units) above what was measured; measured number inside the range.
By their numbers in this assay, from the lowest: compounds 3, 1 and 2 (each within the scatter of the next).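

In this assay, hydrogen in place of methoxy at the position ortho to a methoxy group and meta to a large group gives a 1.6-fold lower number from compound 2 to compound 3 (0.19 log units; within the scatter) and, at a single place, methoxy in place of hydrogen on an aromatic carbon gives a 1.1-fold lower number from compound 1 to compound 3 (0.05 log units; within the scatter) in the same test. Among the compounds shown here, these are the first pairs that differ in one place only, and neither step goes beyond the scatter, so in this test hydrogen and methoxy read as equal at each of these two places. Nothing measured here bears on why these steps stay so small.

On these data alone, whether a group other than methoxy at this position, such as an amine, a hydroxyl or a longer alkoxy chain, would move the number beyond the scatter remains open. As far as these compounds go, all three compounds also keep the rest of the shared core unchanged, so how changes elsewhere on it would read is unknown.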